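Moving one methoxy group: the same change applied twice

The source may hold more compounds than are shown below. What is called first, only, known or untested is meant among the compounds shown, and "the series" means these compounds.

Measured in a functional assay on SW-620 cells (Homo sapiens) for cytotoxicity, read by MTT assay, with a stated time of 72 h; on this read-out higher numbers stand for weaker inhibition and lower numbers for stronger inhibition:
Compound 1 `COc1cccc(/C=C2\CCC/C(=C\c3cccc(OC)c3OC)C2=O)c1` gives 7000 nM.
Compound 2 `COc1ccc(/C=C2\CCC/C(=C\c3cccc(OC)c3OC)C2=O)cc1` gives 13600 nM.
Compound 3 `COc1cccc(/C=C2\CCC/C(=C\c3ccc(OC)c(OC)c3)C2=O)c1` gives 3700 nM.

Compound 2 differs from compound 1 by 4-methoxyphenyl in place of 3-methoxyphenyl on a double-bonded chain carbon bound to a double-bonded ring carbon. In this assay this change made a 1.9-fold higher number from compound 1 to compound 2 (0.29 log units; within the scatter), so the two numbers are not clearly apart. Compound 4 `COc1ccc(/C=C2\CCC/C(=C\c3ccc(OC)c(OC)c3)C2=O)cc1` has not yet been measured; it differs from compound 3 by 4-methoxyphenyl in place of 3-methoxyphenyl on a double-bonded chain carbon bound to a double-bonded ring carbon, the same change at the same place. The difference between the core of compound 1 and the core of compound 3 is not broken down here. Resting on the step of a 1.9-fold higher number from compound 1 to compound 2 (0.29 log units; within the scatter), compound 4 is expected to move by a 1.9-fold higher number from compound 3 to compound 4 (0.28 log units; within the scatter) in this assay. Compound 4 is therefore estimated at 7000 nM, most likely between 3000 nM and 16000 nM.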

Compound 4, half-maximal inhibitory concentration: 6600 nM
Beside the measured number, compound 4's estimate is 1.1-fold (0.03 log units) above it; measured number inside the range.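

In this assay, putting 4-methoxyphenyl in place of 3-methoxyphenyl gives a 1.8-fold higher number from compound 3 to compound 4 (0.25 log units; within the scatter). Set beside the earlier step, the change behaves alike on the two cores: the same change on two cores in this assay, a 1.9-fold higher number (0.29 log units; within the scatter) from compound 1 to compound 2 and a 1.8-fold higher number (0.25 log units; within the scatter) from compound 3 to compound 4, 1.1-fold (0.04 log units) apart, within the scatter of two such steps. Among these compounds, each step alone lies within the scatter, however, so this shows only that two small steps agree on two cores; it does not show that the change truly shifts the number, or that the agreement would hold on any further core.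

The compounds shown leave open what happens when the methoxy group gives way to a different group, such as an amine or a carboxylic acid. They also leave open whether a longer chain in its place would give a step clearly beyond the scatter.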